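Flipping Two Stereocentres in a Trimethoxyphenyl-Rich Tetrahydropyran

This account rests on a few compounds, and the source may have more. Where it says the series, first, only, none or still open, it means among the compounds named here.

The measured compounds and their values:
- compound 1, `COc1ccc(/C=C/C[C@H]2C[C@H]([C@H](O)c3ccc(OC)c(OC)c3)CO[C@@H]2c2ccc(OC)c(OC)c2)cc1OC`: 23500 nM
- compound 2, `O[C@@H](c1ccccc1)[C@H]1CO[C@H](c2ccccc2)[C@@H](C/C=C/c2cccc(F)c2)C1`: 9170 nM
- compound 3, `COc1ccc(/C=C/C[C@H]2C[C@@H]([C@@H](O)c3ccccc3)CO[C@@H]2c2ccccc2)cc1`: 9010 nM

In a functional assay on HL-60 cells (Homo sapiens) for cytotoxicity, read by WST assay, with a stated time of 48 h (on this read-out higher numbers stand for weaker inhibition and lower numbers for stronger inhibition), compound 1 gives the highest of the three numbers, so it is the weakest inhibitor here; compound 2 and compound 3 both sit at lower numbers, by steps that go beyond the scatter.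

Compound 4, `COc1ccc(/C=C/C[C@H]2C[C@@H]([C@@H](O)c3ccc(OC)c(OC)c3)CO[C@@H]2c2ccc(OC)c(OC)c2)cc1OC`, is built from compound 1 by changing configuration only: the two compounds have the same atoms and bonds and differ only in configuration as drawn: 2 of 5 stereo elements differ; a stereocentre at a saturated ring carbon is drawn S in compound 1 and R in compound 4; a stereocentre at a saturated chain carbon is drawn S in compound 1 and R in compound 4. Compound 3 happens to share the drawn configuration of compound 4 at these two centres and gives a lower number than compound 1, but it also carries fewer methoxy groups, so it says nothing clean about the stereochemical change alone.

Among the measured compounds shown here, the only measured step, a 1.0-fold lower number from compound 2 to compound 3 (0.01 log units; within the scatter), concerns an aromatic substituent on the chain, not configuration, and lies within the scatter, so it does not bear on this change. For the measured compounds named here, with no measured step to lean on, the expected move a 1.7-fold lower number from compound 1 to compound 4 (0.22 log units; within the scatter) is uncertain in direction, and compound 4 is estimated at 14000 nM, between 4000 nM and 50000 nM.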

Compound 4, half-maximal inhibitory concentration: 34700 nM
Compound 4: the middle estimate sits 2.5-fold (0.39 log units) below what was measured; the range from low to high includes it.
By their numbers in this assay, from the lowest: compounds 3 and 2 (each within the scatter of the next); then compounds 1 and 4 (each within the scatter of the next).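

Among the compounds shown here, compound 4 gives the first comparison in which configuration is the only variable, and the reading is clean because of one fact: the fact that compounds 1 and 4 differ only in the configuration as drawn. In this assay, inverting the saturated ring carbon and the saturated chain carbon together gives a 1.5-fold higher number from compound 1 to compound 4 (0.17 log units; within the scatter), so on this methoxy-rich structure the two drawn configurations cannot be told apart. Compound 3 could not show this, as it shares the configuration of compound 4 at these two centres but also carries fewer methoxy groups.

The compounds shown leave open whether inverting either centre alone would give a step beyond the scatter, and whether inverting both would do so on the phenyl-bearing structures of compound 2 and compound 3. They also leave open what an amine in place of the hydroxyl group would do at the chain carbon.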